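Working Notes: Cytotoxicity of Three Measured Diols and One Planned

The source may hold more compounds than are shown below. What is called first, only, known or untested is meant among the compounds shown, and "the series" means these compounds.

Measured so far in an ADME assay on S2 cells (Drosophila melanogaster) for cytotoxicity, read by MTT assay; on this read-out lower numbers stand for an effect already at smaller amounts and higher numbers for an effect only at larger amounts of compound:
Compound 1 `CCCCCC[C@H]1C[C@@H](O)[C@@H](O)C1` gives 110000 nM.
Compound 2 `CCCCCCOC(=O)/C=C/[C@H]1C[C@@H](O)[C@@H](O)C1` reaches only an assay limit, > 350000 nM.
Compound 3 `CN(C)C(=O)/C=C/[C@H]1C[C@@H](O)[C@@H](O)C1` reaches only an assay limit, > 250000 nM.

Compound 3 thus stands at a limit of this assay rather than at a number, one of two limits among the three values shown; the other belongs to compound 2, at the limit of > 350000 nM in this assay, at which 1 of the 3 values shown sits. Compound 1 alone supplies a number. Among the measured compounds shown here, no step between two measured compounds that differ in a single place is available, so nothing fixes how far a change on the carbonyl carbon moves the read-out in this assay.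

Compound 4 `O=C(/C=C/[C@H]1C[C@@H](O)[C@@H](O)C1)NC1CC1` has not been measured. It differs from compound 3 by cyclopropylamino in place of dimethylamino on a carbonyl carbon. The expected step of a number no higher from compound 3 to compound 4 (the limit leaves the size open) is none beyond the scatter. Compound 4 is therefore expected to sit near the limit of compound 3, which is the limit of > 250000 nM in this assay, at which 1 of the 3 values shown sits. For compound 4 the estimate in this assay is 250000 nM, with a range from 120000 nM to 500000 nM.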

Compound 4, half-maximal effective concentration: > 250000 nM
Compound 4 gave a limit, no number (the forecaster's own chance of this, stated with the estimate: 60%); the middle value lies on the limit itself.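

In this assay compound 3 stands at the limit > 250000 nM. Among the compounds shown here, compound 4 stands at the limit > 250000 nM, and no step between compound 3 and compound 4 can be read. The compounds shown leave open how far cyclopropylamino in place of dimethylamino on a carbonyl carbon moves this read-out.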